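The source may report more compounds than this note shows. Statements on the series, on what has been measured and on what is new or still open speak of the compounds shown alone.

In a functional assay on A549 cells (Homo sapiens) for inhibition, read by CCK-8 assay, with a stated time of 72 h, tested at 10 uM (on this read-out lower numbers stand for less inhibition of growth and higher numbers for more inhibition of growth at the one concentration tested), the three measured compounds stand as follows:

Compound 1, `Cc1cccc(NC(=O)C2(C(=O)Nc3ccc(Nc4ncc5cc(C(=O)N(C)C)n(C6CCCC6)c5n4)cc3)CC2)c1`: 86.1%
Compound 2, `CN(C)C(=O)c1cc2cnc(Nc3ccc(NC(=O)C4(C(=O)Nc5cccc(F)c5)CC4)cc3)nc2n1C1CCCC1`: 91.8%
Compound 3, `CN(C)C(=O)c1cc2cnc(Nc3ccc(NC(=O)C4(C(=O)Nc5cccc(C#N)c5)CC4)cc3)nc2n1C1CCCC1`: 73.6%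

Compound 2 holds the highest of the three numbers in this assay. Compound 1 lies nearest to it, a number 5.7 percentage points higher from compound 1 to compound 2 (within the scatter), so the two cannot be ordered against each other. Compound 3 lies furthest, a number 18.2 percentage points lower from compound 2 to compound 3 (beyond the scatter), and compound 3 also sits apart from compound 1, a number 12.5 percentage points lower from compound 1 to compound 3 (beyond the scatter).

Compound 4, `CN(C)C(=O)c1cc2cnc(Nc3ccc(NC(=O)C4(C(=O)Nc5cccc(Br)c5)CC4)cc3)nc2n1C1CCCC1`, has not yet been measured. It differs from compound 2 in a single place: bromo in place of fluoro on an aromatic carbon. All three measured steps alter exactly this place on the ring, and they bear on the new change in that they show how much room it leaves: the exchange of methyl for fluoro moved the number only within the scatter, while the entry of cyano lowered it by a modest amount in both measured steps. Going by the values given here, no measured step exchanges fluoro for bromo, so the direction rests on analogy alone. The author therefore expects for compound 4 a step of a number 4.8 percentage points lower from compound 2 to compound 4 (within the scatter), small and more likely downward than upward, though it may well stay within the scatter. The estimate for compound 4 in this assay is 87%, within a range from 74% to 96%.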

Compound 4, percent growth inhibition at one concentration: 92.2%
Estimate against measurement, compound 4: 5.2 percentage points below, and the stated range covers the measured number.
By their numbers in this assay, from the lowest: compound 3; then compounds 1, 2 and 4 (each within the scatter of the next).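

In this assay, the new result shows that this place on the ring, meta to a large group, also accepts bromo without a change that can be read: fluoro and bromo cannot be told apart, with a number 0.4 percentage points higher from compound 2 to compound 4 (within the scatter), and neither can methyl and bromo, with a number 6.1 percentage points higher from compound 1 to compound 4 (within the scatter). Cyano remains the only one of the four groups set apart from the others, and bromo separates from it as clearly as fluoro does, with a number 18.6 percentage points higher from compound 3 to compound 4 (beyond the scatter), so among these compounds methyl, fluoro and bromo form a single set that cannot be ordered, with compound 3 alone lower. Nothing at hand explains why cyano stands apart from the other three groups.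

What the compounds shown leave open is whether a methoxy group, an amine or a carboxylic acid at this place would fall with the set of three or with cyano. Since each number comes from one concentration, they also leave open whether compound 1, compound 2 and compound 4 would separate from one another across a full concentration series.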